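From piperidine back to an aromatic ring

The compounds below may be only part of what the source reports. "The series", "measured", "known", "first", "only" and "open" are said of these compounds alone.

Values in a physicochemical assay for solubility, using the shake flask method, in simulated intestinal fluid, measured as kinetic solubility, with a stated time of 2 h, at 25 degrees C, at pH 6.5; on this read-out higher numbers stand for higher solubility and lower numbers for lower solubility:
- compound 1 `Cc1noc(-c2nc(C)c3c(c2N)C(=O)N(Cc2ccccc2)C3=O)n1`: < 5000 nM (a limit)
- compound 2 `Cc1noc(-c2nc(C)c3c(c2N)C(=O)N(Cc2ccc(-c4ccncc4)cc2)C3=O)n1`: < 5000 nM (a limit)
- compound 3 `Cc1noc(-c2nc(C)c3c(c2N)C(=O)N(CC2CCNCC2)C3=O)n1`: 160000 nM

Within the data shown here, of the three values, only that of compound 3 is a number, 160000 nM. Compound 1 and compound 2 share one mark, (the limit of < 5000 nM in this assay, at which 2 of the 3 values shown sit).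

Compound 4 `Cc1noc(-c2nc(C)c3c(c2N)C(=O)N(Cc2ccc(C(F)(F)F)cc2)C3=O)n1` has not yet been measured in this assay. It differs from compound 3 as follows: 4-(trifluoromethyl)phenyl in place of piperidin-4-yl on a saturated chain carbon bound to an amide-type nitrogen in a ring. The measured step closest to this change is an at least 32-fold higher number from compound 1 to compound 3 (1.50 log units; beyond the scatter). That step puts piperidin-4-yl in the place of phenyl on the same chain carbon, and the change to compound 4 runs the other way, with 4-(trifluoromethyl)phenyl as the entering group. The remaining measured step, a step that the two limits leave unreadable from compound 1 to compound 2, gives no size to work with, though compound 2 also keeps an aromatic ring there.

Among the measured compounds shown here, a large step to a lower number is therefore expected, about as large as the one from compound 1 to compound 3 but reversed. The expected step is a 53-fold lower number from compound 3 to compound 4 (1.73 log units; beyond the scatter). For compound 4 the estimated value is 3000 nM, with an expected range from 800 nM to 7000 nM, and the assay may well report only a limit.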

Compound 4, solubility: < 5000 nM
Compound 4 gave a limit, no number (the forecaster's own chance of this, stated with the estimate: 85%); the middle value does not contradict the limit.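

In this assay, the change at this chain carbon gives an at least 32-fold lower number from compound 3 to compound 4 (1.50 log units; beyond the scatter), so the large gap seen with unsubstituted phenyl also appears with an aromatic ring that carries trifluoromethyl. The steps among compound 1, compound 2 and compound 4 cannot be read, so hydrogen, pyridin-4-yl and trifluoromethyl on the aromatic carbon cannot be ranked against one another. Among the four compounds, the only number belongs to compound 3, with piperidin-4-yl, and none goes against this split, as all three compounds with an aromatic ring at this place share one mark: the limit of < 5000 nM in this assay, at which 3 of the 4 values shown sit.

On these data alone, it remains open whether the high value of compound 3 goes with the ring nitrogen or with the non-aromatic ring, and a cyclohexyl group, which has no nitrogen, or a 4-aminophenyl group, which has an amine on an aromatic ring, on the same chain carbon would separate the two. As far as these compounds go, how far compound 1, compound 2 and compound 4 differ from one another also stays unknown, and an amine or a carboxylic acid in place of trifluoromethyl on the aromatic carbon would show whether a substituent there can lift a value off the limit.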